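The source may hold more compounds than are shown below. What is called first, only, known or untested is meant among the compounds shown, and "the series" means these compounds.

In a physicochemical assay for solubility, read by nephelometry, measured as kinetic solubility, at pH 6.5 (a lower number here means a less soluble compound, a higher number a more soluble compound), compound 1 `CN(C)Cc1csc(NC(=O)c2cc(C(C)(C)C)nn2Cc2ccccc2)n1` gives 25 ug/mL. Compound 2 `NCc1csc(NC(=O)c2cnnn2Cc2ccccc2)n1` gives 50 ug/mL, and compound 3 `Cn1nc(C(C)(C)C)cc1C(=O)Nc1nc(CN)cs1` gives 50 ug/mL. Both of these values lie within the usual scatter of the value for compound 1, so the three cannot be separated on these numbers. Compound 4 `CNCc1csc(NC(=O)c2cc(C(C)(C)C)nn2Cc2ccccc2)n1` keeps the core of compound 1 and differs by hydrogen in place of methyl on an amine nitrogen. Among the compounds with values here, no two measured compounds differ in one place only, so nothing measured shows this change on its own. In this assay, a small upward step, no larger than the scatter, is expected. The estimated change is a 1.6-fold higher number from compound 1 to compound 4 (0.20 log units; within the scatter). For compound 4 the estimate is 40 ug/mL, with an expected range of 20 ug/mL to 85 ug/mL.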

Compound 4, solubility: 12.5 ug/mL
Compound 4: middle estimate off by 3.2-fold (0.51 log units), on the high side; measured number below the stated range.
By their numbers in this assay, from the lowest: compounds 4, 1, 2 and 3 (each within the scatter of the next, the first and the last beyond it).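

In this assay, within the data shown here, hydrogen in place of methyl on an amine nitrogen gives a 2.0-fold lower number from compound 1 to compound 4 (0.30 log units; within the scatter) and is the first single change that can be read on its own. The two compounds cannot be separated on these numbers, so dimethylamino and methylamino are indistinguishable at this position. Nothing available explains the result.

The compounds shown leave open whether a longer chain on this nitrogen, such as ethyl, or a morpholine ring in place of dimethylamino would give a step beyond the scatter.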